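Trading the Diethylamino Chain End for Hydroxy

This account rests on a few compounds, and the source may have more. Where it says the series, first, only, none or still open, it means among the compounds named here.

In a functional assay on L1210 cells (Mus musculus) for inhibition (a lower number here means a stronger inhibitor, a higher number a weaker inhibitor), compound 1 `COC1=CC(=O)c2ncnc(NCCCN(C)C)c2C1=O` gives 0.501 ug/mL and compound 2 `CCN(CC)CCCNc1ncnc2c1C(=O)C(OC)=CC2=O` gives 0.393 ug/mL. For the measured compounds named here, compound 2 therefore stands within the scatter of compound 1, the only other compound measured so far. Compound 3 `COC1=CC(=O)c2ncnc(NCCO)c2C1=O` shares the core of compound 2 but differs in its side chain, as follows: hydroxy in place of (diethylamino)methyl on a saturated chain carbon, two bonds along the chain from a nitrogen on an aromatic ring. This places hydroxy in place of (diethylamino)methyl on a saturated chain carbon, two bonds along the chain from a nitrogen on an aromatic ring.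

Going by the values given here, only one measured step bears on this change, a 1.3-fold lower number from compound 1 to compound 2 (0.11 log units; within the scatter). That step exchanges dimethylamino for diethylamino, so both of its compounds still carry an amino group at the chain end. Among the compounds with values here, no measured compound lacks such a group, and the data therefore do not size the change directly. A move towards a higher number is expected, but only tentatively, and the uncertainty is wide. The change is estimated as a 2.5-fold higher number from compound 2 to compound 3 (0.41 log units; beyond the scatter). For compound 3, the expected value is 1 ug/mL, with an estimated range of 0.25 ug/mL to 5 ug/mL.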

Compound 3, half-maximal inhibitory concentration: 1.78 ug/mL
Beside the measured number, compound 3's estimate is 1.8-fold (0.25 log units) below it, within the range that was stated.
By their numbers in this assay, from the lowest: compounds 2 and 1 (each within the scatter of the next); then compound 3.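

In this assay, for the compounds shown here, the replacement of the amine-bearing chain end by hydroxy is the first change at this position to move the number beyond the scatter, towards a weaker inhibitor (a 4.5-fold higher number from compound 2 to compound 3 (0.66 log units; beyond the scatter)). The same direction appears from the dimethylamino side (a 3.6-fold higher number from compound 1 to compound 3 (0.55 log units; beyond the scatter)), so the result does not depend on which of the two amines is the starting point, whereas the exchange of one amine for the other had stayed within the scatter. No measurement is available that would account for this rise in the number, so the result stands here as an observation only.

What the compounds shown leave open is which part of the change carries the step, since the amine is lost and the chain is shortened in the same move, from 2-(diethylamino)ethyl to hydroxymethyl. A longer chain ending in hydroxy, or the shorter chain ending in diethylamino, would separate the two, and a chain ending in a carboxylic acid or a methoxy group would show how far the trend extends beyond hydroxy.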